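The source may report more compounds than this note shows. Statements on the series, on what has been measured and on what is new or still open speak of the compounds shown alone.

Compound 1 `COc1nc2ccc(Br)cc2cc1C(c1ccccc1)n1cc(CCO)nn1` — in an ADME assay on HeLa cells (Homo sapiens) for cytotoxicity, read by sulforhodamine B assay, with a stated time of 48 h, tested at 10 uM (on this read-out lower numbers stand for less inhibition and higher numbers for more inhibition at the one concentration tested (going by the name of the read-out)), compound 1 gives 0.85%
Compound 2 `COc1nc2ccc(Br)cc2cc1C(c1ccccc1)n1cc(-c2cccc(F)c2)nn1` — in this assay compound 2 gives 9.04%
Compound 3 `COc1nc2ccc(Br)cc2cc1C(c1ccccc1)n1cc(-c2ccc(F)cc2)nn1` — in this assay compound 3 gives 4.27%

Compound 3 stands second highest of the three numbers in this assay, yet its neighbours are close: a number 3.4 percentage points higher from compound 1 to compound 3 (within the scatter) and a number 4.8 percentage points lower from compound 2 to compound 3 (within the scatter) both lie within the scatter. Compound 4 `COc1nc2ccc(Br)cc2cc1C(c1ccccc1)n1cc(C2CC2)nn1` is not yet measured; it differs from compound 3 by cyclopropyl in place of 4-fluorophenyl on an aromatic carbon. Among the measured compounds shown here, no measured step swaps a fluorophenyl for a cyclopropyl, so none bears directly on this change. What is known is that every measured step, a number 8.2 percentage points higher from compound 1 to compound 2 (within the scatter) among them, stayed within the scatter, even where 2-hydroxyethyl was replaced by a fluorophenyl. On that basis no step beyond the scatter is expected in this assay. Compound 4 is therefore estimated to give 3.5% in this assay, with a range from 0% to 12%. The expected step is a number 0.8 percentage points lower from compound 3 to compound 4 (within the scatter).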

Compound 4, a percentage reported as inhibition, at one concentration (the size of the read-out at that concentration, not a potency): -5.84%
Compound 4: middle estimate off by 9.3 percentage points, on the high side; the measured number lies below the stated range.
By their numbers in this assay, from the lowest: compounds 4, 1, 3 and 2 (each within the scatter of the next, the first and the last beyond it).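

Among the compounds shown here, at this carbon of the five-membered aromatic ring, cyclopropyl brings the first steps beyond the scatter in this assay with a number 10.1 percentage points lower from compound 3 to compound 4 (beyond the scatter) and a number 14.9 percentage points lower from compound 2 to compound 4 (beyond the scatter) while the change from 2-hydroxyethyl stays within it with a number 6.7 percentage points lower from compound 1 to compound 4 (within the scatter) as its step. The read-out at this position therefore does separate cyclopropyl from either fluorophenyl, though only modestly. No measurement at hand accounts for this difference.

From the compounds shown here alone, whether an amine, a carboxylic acid or a longer alkyl chain at this carbon would stay close to compound 4 or to compound 2 remains open.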